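Notes on the triazole change from compound 2 to compound 4

A few compounds are considered here, and "the series" means these few. Any claim that something is new, unique, unknown or untested is made for them only; others in the source may bear on it.

Measured so far:
Compound 1 `CN(C)CCn1cnnc1-c1cc(Oc2ccc(NC(=O)N/N=C/c3ccccc3)cc2F)ccn1` gives 1780 nM in a functional assay on NCI-H460 cells (Homo sapiens) for cytotoxicity, read by MTT assay, with a stated time of 72 h; on this read-out higher numbers stand for weaker inhibition and lower numbers for stronger inhibition.
Compound 2 `Cn1ncnc1-c1cc(Oc2ccc(NC(=O)N/N=C/c3ccccc3)cc2F)ccn1` gives 52200 nM in this assay.
Compound 3 `CN(C)CCn1cnnc1-c1cc(Oc2ccc(NC(=O)N/N=C/c3ccc(F)cc3Cl)cc2F)ccn1` gives 720 nM in this assay.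

Compound 2 stands highest of the three numbers in this assay; its nearest neighbour is compound 1, its furthest compound 3. Compound 4 `Cn1cnnc1-c1cc(Oc2ccc(NC(=O)N/N=C/c3ccccc3)cc2F)ccn1` differs from compound 2 by 4-methyl-4H-1,2,4-triazol-3-yl in place of 1-methyl-1H-1,2,4-triazol-5-yl on an aromatic carbon. Within the data shown here, no measured step covers this change on its own. The step of a 29-fold higher number from compound 1 to compound 2 (1.47 log units; beyond the scatter) combines the same triazole change with a change of the group on the triazole, so it gives only an upper bound on the effect; the step of a 2.5-fold lower number from compound 1 to compound 3 (0.39 log units; beyond the scatter) concerns another part of the molecule and does not bear on it. Compound 4 shares the triazole attachment of compound 1 and the methyl of compound 2, so a number between the two is expected, a step of a 3.5-fold lower number from compound 2 to compound 4 (0.54 log units; beyond the scatter). Compound 4 is therefore estimated at 15000 nM, with a range from 4000 nM to 50000 nM.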

Compound 4, half-maximal inhibitory concentration: 15700 nM
Compound 4: the middle estimate sits 1.0-fold (0.02 log units) below what was measured; measured number inside the range.
By their numbers in this assay, from the lowest: compound 3; then compound 1; then compound 4; then compound 2.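

In this assay, the triazole change now has a size of its own: a 3.3-fold lower number from compound 2 to compound 4 (0.52 log units; beyond the scatter), with the methyl group kept. The side chain also separates out: an 8.8-fold higher number from compound 1 to compound 4 (0.95 log units; beyond the scatter), with hydrogen in place of (dimethylamino)methyl. Both changes are beyond the scatter, so a 29-fold higher number from compound 1 to compound 2 (1.47 log units; beyond the scatter) holds two distinct contributions.

No measurement shown gives a reason for either step. Going by these compounds, it remains open whether a pyrrolidine in place of the dimethylamino group would keep the lower number, and whether the triazole step holds with the 2-chloro-4-fluorophenyl group of compound 3.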